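From piperidin-3-yl to 3,5-difluorobenzyl on the amide

The source may report more compounds than this note shows. Statements on the series, on what has been measured and on what is new or still open speak of the compounds shown alone.

In a functional assay on EBC-1 cells (Homo sapiens) for antiproliferative activity, with a stated time of 72 h (on this read-out higher numbers stand for weaker inhibition and lower numbers for stronger inhibition), compound 1 `CN(C)CCNC(=O)c1ccc(-c2cc(F)c3ncc(Cc4ccc5ncccc5c4)n3c2)cc1F` gives 49 nM, compound 2 `O=C(NCC1CCCCN1)c1ccc(-c2cc(F)c3ncc(Cc4ccc5ncccc5c4)n3c2)cc1F` gives 277 nM and compound 3 `O=C(NC1CCCNC1)c1ccc(-c2cc(F)c3ncc(Cc4ccc5ncccc5c4)n3c2)cc1F` gives 138 nM. The standing of that last value shows in two steps: a 2.0-fold lower number from compound 2 to compound 3 (0.30 log units; within the scatter), and a 2.8-fold higher number from compound 1 to compound 3 (0.45 log units; beyond the scatter). Compound 4 `O=C(NCc1cc(F)cc(F)c1)c1ccc(-c2cc(F)c3ncc(Cc4ccc5ncccc5c4)n3c2)cc1F` carries 3,5-difluorobenzyl in place of piperidin-3-yl on an amide-type nitrogen. The largest measured step among these groups is modest: a 5.7-fold higher number from compound 1 to compound 2 (0.75 log units; beyond the scatter). Going by the values given here, no measured step puts an aromatic ring on that nitrogen, so these steps guide only loosely, and no clear move beyond the scatter is expected in this assay. The estimated step is a 1.1-fold higher number from compound 3 to compound 4 (0.04 log units; within the scatter). For compound 4 the expected value is 150 nM, with an estimated range of 30 nM to 700 nM.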

Compound 4, half-maximal inhibitory concentration: 53.6 nM
For compound 4 the middle estimate is 2.8-fold (0.45 log units) above the measured one; the measured number falls inside the stated range.
By their numbers in this assay, from the lowest: compounds 1 and 4 (each within the scatter of the next); then compounds 3 and 2 (each within the scatter of the next).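

In this assay an aromatic ring without nitrogen serves well on this amide-type nitrogen: the number falls relative to both piperidine compounds (a 2.6-fold lower number from compound 3 to compound 4 (0.41 log units; beyond the scatter); a 5.2-fold lower number from compound 2 to compound 4 (0.71 log units; beyond the scatter)) and stays level with the dimethylamino chain (a 1.1-fold higher number from compound 1 to compound 4 (0.04 log units; within the scatter)). A nitrogen in this group is therefore not needed to reach the lowest numbers seen here. No measurement on hand explains this change.

The compounds shown leave open whether the ring alone or its fluorine atoms carry the step, which plain benzyl would separate. As far as these compounds go, whether a carboxylic acid would be accepted on this nitrogen's chain also stays open.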